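The compounds below may be only part of what the source reports. "The series", "measured", "known", "first", "only" and "open" are said of these compounds alone.

Of the compounds shown here, three of a shared core have been tested in a functional assay on SJSA-1 cells (Homo sapiens) for inhibition, read by CCK-8 assay, with a stated time of 72 h, tested at 1 uM; on this read-out higher numbers stand for more inhibition at the one concentration tested (going by the name of the read-out) and lower numbers for less inhibition. Compound 1 `COc1ccc(F)cc1N1C(=O)CSC1c1cccc(C(=O)NCCCCc2ccccc2)c1` gives 76%, compound 2 `Cc1cccc(N2C(=O)CSC2c2cccc(C(=O)NCCCCc3ccccc3)c2)c1` gives 84%, and compound 3 `COc1cc(F)ccc1N1C(=O)CSC1c1cccc(C(=O)NCCCCc2ccccc2)c1` gives 77%. By the bare numbers compound 3 comes second of the three, yet its closeness to compound 1 is described by a number 1 percentage points higher from compound 1 to compound 3 (within the scatter) and its distance from compound 2 by a number 7 percentage points lower from compound 2 to compound 3 (within the scatter), so the three compounds cannot be told apart in this assay.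

Compound 4 `O=C(NCCCCc1ccccc1)c1cccc(C2SCC(=O)N2c2cccc(F)c2)c1` differs from compound 3 in one place: 3-fluorophenyl in place of 4-fluoro-2-methoxyphenyl on an amide-type nitrogen in a ring. Two measured steps speak to a change of the group on that ring nitrogen. One is a number 8 percentage points higher from compound 1 to compound 2 (within the scatter), the other a number 7 percentage points lower from compound 2 to compound 3 (within the scatter); both are within the scatter, and no exchange of this ring so far has moved the number beyond it. For compound 4 a step of a number 1 percentage points higher from compound 3 to compound 4 (within the scatter) is therefore expected, none beyond the scatter. Compound 4 is estimated at 78%, with a range from 65% to 90%.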

Compound 4, a percentage reported as inhibition, at one concentration (the size of the read-out at that concentration, not a potency): 80%
Compound 4: middle estimate off by 2 percentage points, on the low side; the range from low to high includes it.
By their numbers in this assay, from the lowest: compounds 1, 3, 4 and 2 (each within the scatter of the next).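

In this assay, 3-fluorophenyl in place of 4-fluoro-2-methoxyphenyl on the amide-type nitrogen gives a number 3 percentage points higher from compound 3 to compound 4 (within the scatter) and so shows that a phenyl ring without methoxy stays within the scatter of the methoxy-bearing compounds. Hydrogen in place of methoxy gives a number 4 percentage points higher from compound 1 to compound 4 (within the scatter) and fluoro in place of methyl gives a number 4 percentage points lower from compound 2 to compound 4 (within the scatter), so neither single exchange on this ring separates compound 4 from its neighbours. No measurement at hand offers an explanation for this result.

On these data alone, whether an amine or a carboxylic acid on this phenyl ring would carry the number beyond the scatter remains open, as does the effect of replacing the ring with a simple alkyl chain. With readings at a single concentration, the compounds' potencies also remain unresolved.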